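The compounds below may be only part of what the source reports. "The series", "measured", "known", "first", "only" and "open" are said of these compounds alone.

Measured in an ADME assay on Raji cells (Homo sapiens) for cytotoxicity, with a stated time of 72 h (on this read-out lower numbers stand for an effect already at smaller amounts and higher numbers for an effect only at larger amounts of compound), each value being a limit:

Compound 1 `O=C(Nc1ccc(F)c(-c2nc3ccccc3o2)c1)c1cc([N+](=O)[O-])ccc1Cl`: > 25000 nM, a limit.
Compound 2 `O=C(Nc1nc2ccc(Cl)cc2s1)c1cc([N+](=O)[O-])ccc1Cl`: > 27000 nM, a limit.
Compound 3 `O=C(Nc1ccc(F)c(-c2nc3ccccc3s2)c1)c1cc([N+](=O)[O-])ccc1Cl`: > 25000 nM, a limit.

Compound 3 offers no number to start from, only a limit, and the other two compounds offer no more. The values gather at two limits: the limit of > 25000 nM in this assay, at which 2 of the 3 values shown sit, and (the limit of > 27000 nM in this assay, at which 1 of the 3 values shown sits).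

Compound 4 `COc1ccc(NC(=O)c2cc([N+](=O)[O-])ccc2Cl)cc1-c1nc2ccccc2s1` differs from compound 3 in one substituent: methoxy in place of fluoro on an aromatic carbon. This puts methoxy in place of fluoro on an aromatic carbon, ortho to a 1,3-benzothiazol-2-yl group and para to a large group.

Among the compounds with values here, no measured step bears directly on this exchange. Within the data shown here, the only one available is a step that the two limits leave unreadable from compound 1 to compound 3, which concerns a different group and has no readable size. Nothing in this assay therefore points to a direction, and no step beyond the usual scatter is expected. The expectation rests on compound 3 and its limit of > 25000 nM. The expected step is an at least 1.1-fold lower number from compound 3 to compound 4 (0.05 log units; that floor lies within the scatter), and compound 4 may well be reported only as a limit too. For compound 4 the estimate is 22000 nM, with an expected range from 8000 nM to 30000 nM.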

Compound 4, half-maximal effective concentration in the Raji assay: > 25000 nM
Compound 4: only a limit was reported; the forecaster's own chance of this, stated with the estimate: 80%; at least 1.1-fold (0.05 log units) between middle value and limit.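

In the Raji assay compound 4 is reported only as a limit (> 25000 nM). Within the data shown here, compound 3 likewise has only a limit there, so no step from compound 3 to compound 4 can be read. In a physicochemical assay for solubility, read by spectrophotometry, in phosphate buffer, measured as kinetic solubility, with a stated time of 18 h, at pH 7.4 (on this read-out lower numbers stand for lower solubility and higher numbers for higher solubility), compound 3 gives 490 nM and compound 4 gives 260 nM (this is a 1.9-fold lower number from compound 3 to compound 4 (0.28 log units; within the scatter)). In the Raji assay the compounds shown leave open at what concentration any of them would reach a half-maximal effect, because the values gather at a limit: the limit of > 25000 nM in the Raji assay, at which 3 of the 4 values shown sit.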